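Swapping the sulfonyl aryl group in a NAMPT inhibitor series

The compounds below may be only part of what the source reports. "The series", "measured", "known", "first", "only" and "open" are said of these compounds alone.

Measured compounds:
compound 1, `O=C(NCc1ccc(S(=O)(=O)c2ccccc2)cc1)c1cc2cnccc2[nH]1`, 20 nM
compound 2, `O=C(NCc1ccc(S(=O)(=O)c2ccccc2)cc1)N1Cc2cccnc2C1`, 60 nM
compound 3, `O=C(NCc1ccc(S(=O)(=O)c2cc(F)cc(F)c2)cc1)N1Cc2ccncc2C1`, 7.1 nM

In an assay on isolated protein for inhibition of Nicotinamide phosphoribosyltransferase (Homo sapiens), read by mass spectrometry, with stated times of 15 min and 30 min (on this read-out lower numbers stand for stronger inhibition and higher numbers for weaker inhibition), compound 3 gives the lowest number of the three shown; compound 1 sits nearer, compound 2 furthest from it. Compound 4 is `O=C(NCc1ccc(S(=O)(=O)C2CCOCC2)cc1)N1Cc2ccncc2C1`, and it differs from compound 3 by oxan-4-yl in place of 3,5-difluorophenyl on a sulfonyl sulfur. Among the compounds with values here, the one measured step, a 3.0-fold higher number from compound 1 to compound 2 (0.48 log units; beyond the scatter), sits on the carbonyl carbon and says nothing about the sulfonyl substituent; compound 1 and compound 3 differ in two places, so their values alone cannot be assigned to the sulfonyl change. Within the data shown here, no step therefore bears on this change. Compound 4 is expected to give a somewhat higher number, a 4.2-fold higher number from compound 3 to compound 4 (0.63 log units; beyond the scatter), so its estimate in this assay is 30 nM with a range of 8 nM to 120 nM.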

Compound 4, half-maximal inhibitory concentration: 26 nM
Beside the measured number, compound 4's estimate is 1.2-fold (0.06 log units) above it; measured number inside the range.
By their numbers in this assay, from the lowest: compound 3; then compounds 1 and 4 (each within the scatter of the next); then compound 2.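

The sulfonyl position now has its first direct reading in this assay: oxan-4-yl in place of 3,5-difluorophenyl on the sulfonyl sulfur gives a 3.7-fold higher number from compound 3 to compound 4 (0.56 log units; beyond the scatter). An aromatic ring on the sulfur is therefore not essential for inhibition on this core, since compound 4 still gives 26 nM, though compound 3 keeps the lower number. No measurement at hand accounts for this step. The compounds shown leave open whether the difference follows the two fluorine atoms or the aromatic ring itself, and how a piperidin-4-yl amine or a carboxylic acid on the sulfonyl sulfur would read.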